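A few compounds are considered here, and "the series" means these few. Any claim that something is new, unique, unknown or untested is made for them only; others in the source may bear on it.

In a functional assay on HepG2 cells (Homo sapiens) for antiproliferative activity, read by MTT assay, with a stated time of 48 h (on this read-out lower numbers stand for stronger inhibition and higher numbers for weaker inhibition), the three measured compounds gave the following results:

Compound 1, `N#CC1=C(N)Oc2c(c3nc4ccccc4nc3c3ccccc23)C12C(=O)N(Cc1cnnn1-c1ccc(F)cc1)c1ccccc12`, gave > 50000 nM, which is a limit of the assay.
Compound 2, `N#CC1=C(N)Oc2c(c3nc4ccccc4nc3c3ccccc23)C12C(=O)N(Cc1cnnn1-c1ccccc1Br)c1ccccc12`, gave > 50000 nM, which is a limit of the assay.
Compound 3, `N#CC1=C(N)Oc2c(c3nc4ccccc4nc3c3ccccc23)C12C(=O)N(Cc1cnnn1-c1cccc(Br)c1)c1ccccc12`, gave > 50000 nM, which is a limit of the assay.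

Compound 3 therefore stands at the assay limit, and it is not alone there: the limit of > 50000 nM in this assay, at which 3 of the 3 values shown sit. No real number exists for any of the three, so none of them can be ranked against another.

The next compound, compound 4, is `COc1ccccc1-n1nncc1CN1C(=O)C2(C(C#N)=C(N)Oc3c2c2nc4ccccc4nc2c2ccccc32)c2ccccc21`. It differs from compound 3 in one place: 2-methoxyphenyl in place of 3-bromophenyl on an aromatic nitrogen. The measured steps that touch this position are a step that the two limits leave unreadable from compound 1 to compound 2, a step that the two limits leave unreadable from compound 1 to compound 3 and a step that the two limits leave unreadable from compound 2 to compound 3. Each of them joins two limits, so none of them shows a size or a direction, and they carry no information about what a further change of the group on the aromatic nitrogen does in this assay. There is thus no measured ground for expecting compound 4 to move away from the limit in either direction.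

Compound 4 is therefore expected to give about 50000 nM, within a range from 15000 nM to 200000 nM, most probably again reported only as a limit. The expected step, a number no higher from compound 3 to compound 4 (the limit leaves the size open), is an estimate of no readable change.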

Compound 4, half-maximal inhibitory concentration: > 50000 nM
Compound 4: no number, only a limit (the forecaster's own chance of this, stated with the estimate: 80%); the middle value sits exactly at the limit.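

In this assay compound 4 gives > 50000 nM and this is a limit of the assay, not a number. Going by these compounds alone, its steps from compound 1, compound 2 and compound 3 cannot be read, as no compound here has a real number: the limit of > 50000 nM in this assay, at which 4 of the 4 values shown sit. The compounds shown leave open whether any group on the aromatic nitrogen changes antiproliferative activity on the shared core, and by how much.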